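A few compounds are considered here, and "the series" means these few. Any claim that something is new, unique, unknown or untested is made for them only; others in the source may bear on it.

Among the measured compounds shown here, compound 2 `N=C(NCCCc1c[nH]cn1)NCCC(c1ccc(Cl)c(Cl)c1)c1ccccn1` gives the lowest of the two numbers so far: in a functional assay on ileum for antagonist activity at histamine H1 receptor (Cavia porcellus) (on this read-out higher numbers stand for weaker binding and lower numbers for tighter binding), compound 2 gives 79.4 nM, while compound 1 `N=C(NCCCc1c[nH]cn1)NCCC(c1ccc(C(F)(F)F)cc1)c1ccccn1` gives 282 nM. For the measured compounds named here, the one step in hand, a 3.6-fold lower number from compound 1 to compound 2 (0.55 log units; beyond the scatter), shows that swapping the aryl group on the saturated chain carbon moves this assay by a modest amount. Compound 3 `N=C(NCCCc1c[nH]cn1)NCCC(c1ccccn1)c1cccs1` carries the change (thiophen-2-yl in place of 3,4-dichlorophenyl on a saturated chain carbon bound to an aromatic carbon and a saturated chain carbon). As the same position is varied, a step of similar size is expected, most likely toward a higher number, since the entering ring is the smaller one. For compound 3 the expected value in this assay is 200 nM, within 60 nM to 700 nM, corresponding to an expected step of a 2.5-fold higher number from compound 2 to compound 3 (0.40 log units; beyond the scatter).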

Compound 3, dissociation constant: 45.7 nM
Estimate against measurement, compound 3: 4.4-fold (0.64 log units) above, and the stated range ends above it.
By their numbers in this assay, from the lowest: compounds 3 and 2 (each within the scatter of the next); then compound 1.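

At this saturated chain carbon, thiophen-2-yl and 3,4-dichlorophenyl cannot be told apart in this assay, with a 1.7-fold lower number from compound 2 to compound 3 (0.24 log units; within the scatter) as the step between them. Thiophen-2-yl also holds a clear edge over 4-(trifluoromethyl)phenyl, with a 6.2-fold lower number from compound 1 to compound 3 (0.79 log units; beyond the scatter) beyond the scatter, so among these three groups only the one in compound 1 stands apart. No measurement in hand explains this result.

From the compounds shown here alone, whether plain phenyl or cyclohexyl at this carbon keeps the level of compound 2 and compound 3 stays open. So does the effect of an amine or a carboxylic acid on the ring.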